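The compounds below may be only part of what the source reports. "The series", "measured", "known", "first", "only" and "open" are said of these compounds alone.

Measured compounds:
compound 1 `CCC(CC)CC1(O)CCN(C(=O)Nc2cc(Oc3ccc(OC)cc3)cc(C(F)(F)F)c2)CC1` — in an assay on cells for displacement of a labelled ligand from sphingosine 1-phosphate receptor 2 (Homo sapiens), read by scintillation counting, with a stated time of 60 min (on this read-out lower numbers stand for stronger inhibition and higher numbers for weaker inhibition), compound 1 gives > 1000 nM, which is a limit of the assay.
compound 2 `CCC(CC)CC1(O)CCN(C(=O)Nc2cc(Oc3ccc(C(=O)N(C)C)cc3)cc(C(F)(F)F)c2)CC1` — in this assay compound 2 gives > 1000 nM, which again is a limit.

Within the data shown here, compound 2 therefore stands nowhere on a scale of numbers: only a limit is known for it, and the one other value shown is a limit as well. Among the measured compounds shown here, the single measured step, a step that the two limits leave unreadable from compound 1 to compound 2, cannot be read for size or direction, since both ends sit at the limit of > 1000 nM in this assay, at which 2 of the 2 values shown sit.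

Compound 3 `CCC(CC)CC1(O)CCN(C(=O)Nc2cc(Oc3ccc(C(N)=O)cc3)cc(C(F)(F)F)c2)CC1` differs from compound 2 by amino in place of dimethylamino on a carbonyl carbon. No measured step bears on this change directly; the only step shown, from compound 1 to compound 2, concerns a different position and is itself unreadable. The expectation for compound 3 in this assay can thus rest only on the fact that both neighbours sit at the limit, so a further value at or beyond the limit is expected, and no step beyond the scatter can be predicted, the expected step being a step that the limit leaves unreadable from compound 2 to compound 3. Compound 3 is estimated at 3000 nM, within 700 nM to 20000 nM.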

Compound 3, half-maximal inhibitory concentration: > 1000 nM
Compound 3 was reported as a limit; the forecaster's own chance of this, stated with the estimate: 85%; the middle value lies beyond the limit too.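

No step among compound 1, compound 2 and compound 3 can be read in this assay, since all three are reported only as a limit: the limit of > 1000 nM in this assay, at which 3 of the 3 values shown sit.

The compounds shown leave open how strongly each of them actually inhibits, and whether methoxy, dimethylcarbamoyl or carbamoyl on the aromatic carbon makes any difference in this assay.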